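The compounds below may be only part of what the source reports. "The series", "measured", "known", "first", "only" and "open" are said of these compounds alone.

Measured so far in a functional assay on the whole organism with Scenedesmus acutus as the target, read by spectrophotometry; a higher number here means a weaker inhibitor, a lower number a stronger inhibitor:
- Compound 1 `O=c1c2c(sn1-c1cc(OC3CCCC3)c(Cl)cc1F)CCCC2`: 9550 nM
- Compound 2 `CC(C)OC(=O)c1cc(N2C(=O)C3=C(CCCC3)C2=O)ccc1Cl`: 1000 nM
- Compound 3 `O=c1c2c([s+]([O-])n1-c1cc(OC3CCCC3)c(Cl)cc1F)CCCC2`: 4790 nM

These three numbers place compound 1 at the weak end of this small set, though not alone. Compound 1 at 9550 nM and compound 3 at 4790 nM lie within the usual scatter of repeated measurements of each other. Compound 2 at 1000 nM has a lower number than either of them, and its gap to compound 1 is beyond the scatter, so it is the stronger inhibitor of that pair.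

The next compound to be tested is compound 4 `O=c1c2c(sn1-c1ccc(Cl)cc1F)CCCC2`. It is compound 1 with hydrogen in place of cyclopentyloxy on an aromatic carbon. For the measured compounds named here, no pair of measured compounds shows this change, so the data offer no direct guide to its size. The expectation rests only on the change itself: a sizeable group leaves and nothing of similar size enters. A weaker inhibitor is therefore expected, meaning a higher number in this assay, by a step beyond the scatter. The estimate amounts to a 3.1-fold higher number from compound 1 to compound 4 (0.50 log units; beyond the scatter). For compound 4 the expected value is 30000 nM, with an estimated range from 10000 nM to 100000 nM.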

Compound 4, half-maximal inhibitory concentration: 20400 nM
Compound 4: the middle estimate sits 1.5-fold (0.17 log units) above what was measured; the measured number falls inside the stated range.
By their numbers in this assay, from the lowest: compound 2; then compounds 3 and 1 (each within the scatter of the next); then compound 4.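

For the compounds shown here, until now, no two compounds in this assay differed in only one place, so this pair gives the first direct reading of what cyclopentyloxy contributes on this aromatic carbon, ortho to the chloro group and para to the fluoro group. Replacing it with hydrogen gives a 2.1-fold higher number from compound 1 to compound 4 (0.33 log units; beyond the scatter), a modest step but one beyond the scatter, so the group makes a real difference to the measured number, although inhibition does not vanish without it: compound 4 still gives a measurable 20400 nM. Nothing measured here explains why the step has this size.

As far as these compounds go, only two substituents are compared at this position, hydrogen and cyclopentyloxy, so it remains open whether a methoxy group, a longer chain such as butoxy, or a phenoxy group would give a number between those of compound 4 and compound 1 or one beyond them. Going by these compounds alone, the step is also seen on only one form of the core, so it remains open whether the same replacement would have a similar effect on compound 3.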